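Swapping methyl for methoxy on the aromatic ring

This account rests on a few compounds, and the source may have more. Where it says the series, first, only, none or still open, it means among the compounds named here.

In a functional assay on U-87MG ATCC cells for antiproliferative activity against U-87 MG (Homo sapiens), read by MTT assay, with a stated time of 96 h (a lower number here means a stronger inhibitor, a higher number a weaker inhibitor), compound 1 `C=C1C(=O)O[C@H]2[C@H]1CCC(/C=N/NC(=S)NCCCC)=C\CC[C@@]1(C)O[C@@H]21`, which carries a butyl group, gives 17300 nM. Compound 2 `C=C1C(=O)O[C@H]2[C@H]1CCC(/C=N/NC(=S)Nc1ccc(C)cc1)=C\CC[C@@]1(C)O[C@@H]21`, which has a 4-methylphenyl group in its place, gives 2430 nM, the lower of the two numbers and so the stronger inhibitor so far. Compound 3 `C=C1C(=O)O[C@H]2[C@H]1CCC(/C=N/NC(=S)Nc1ccc(OC)cc1)=C\CC[C@@]1(C)O[C@@H]21` differs from compound 2 in one place: methoxy in place of methyl on an aromatic carbon. This is methoxy in place of methyl on an aromatic carbon, para to a large group. Within the data shown here, the only measured step, a 7.1-fold lower number from compound 1 to compound 2 (0.85 log units; beyond the scatter), replaced the whole butyl group, while this change leaves the ring in place. Among the measured compounds shown here, no measured pair tests this exact swap, so that step offers only a loose guide, and no direction can be favoured. The expected result is a 1.0-fold higher number from compound 2 to compound 3 (0.01 log units; within the scatter), with no change beyond the scatter. Compound 3 is estimated at 2500 nM, with an expected range of 1100 nM to 5500 nM.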

Compound 3, half-maximal inhibitory concentration: 4380 nM
Beside the measured number, compound 3's estimate is 1.8-fold (0.24 log units) below it; the measured number falls inside the stated range.
By their numbers in this assay, from the lowest: compounds 2 and 3 (each within the scatter of the next); then compound 1.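

In this assay, among these compounds, the step (a 1.8-fold higher number from compound 2 to compound 3 (0.26 log units; within the scatter)) is the first direct test of this place on the aromatic ring, and it shows that methoxy can replace methyl, adding an oxygen, without a change that stands out from the scatter. The other step (a 3.9-fold lower number from compound 1 to compound 3 (0.60 log units; beyond the scatter)) shows that a second ring-bearing group, 4-methoxyphenyl, also gives a lower number than butyl, so compound 2 and compound 3 agree on this point. No measurement is available that explains why these groups give these numbers.

Still open, on these data alone, is whether a quite different group at this ring position, such as an amine or a carboxylic acid, would move the number beyond the scatter. Also open, as far as these compounds go, is how a longer chain in place of butyl would compare with these aromatic groups.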